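The source may hold more compounds than are shown below. What is called first, only, known or untested is meant among the compounds shown, and "the series" means these compounds.

Measured compounds so far:
compound 1 `Cc1cc(Cc2cccs2)c(=O)n(CC(=O)Nc2ccc(Br)cc2)n1`: in a functional assay on HL-60 cells (Homo sapiens), read by calcium flux (a higher number here means that more compound is needed for the effect, a lower number that less compound is needed), compound 1 gives > 50000 nM, which is a limit of the assay.
compound 2 `Cc1cc(Cc2cccnc2)c(=O)n(CC(=O)Nc2ccc(Br)cc2)n1`: in this assay compound 2 gives > 50000 nM, again a limit of the assay.

Within the data shown here, compound 2 therefore stands only at a limit, and the single further value shown is also a limit, so that (the limit of > 50000 nM in this assay, at which 2 of the 2 values shown sit). The step that the two limits leave unreadable from compound 1 to compound 2 cannot be read in size or direction.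

Compound 3 `COc1ccc(-c2cc(C)nn(CC(=O)Nc3ccc(Br)cc3)c2=O)cc1` differs from compound 2 by 4-methoxyphenyl in place of (pyridin-3-yl)methyl on an aromatic carbon. Among the measured compounds shown here, no measured step bears on this change: the one step recorded concerns a different group and is itself hidden behind two limits. No direction and no size beyond the scatter can be grounded in the numbers shown. With both measured compounds sitting at the limit, compound 3 is expected most likely to sit there as well, while a readable value cannot be excluded. The estimate for compound 3 is 40000 nM, within 5000 nM to 100000 nM. The implied step an at least 1.2-fold lower number from compound 2 to compound 3 (0.09 log units; that floor lies within the scatter) is an expectation only, taken from a limit.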

Compound 3, half-maximal effective concentration: > 50000 nM
Compound 3: only a limit was reported (the forecaster's own chance of this, stated with the estimate: 70%); middle value at least 1.2-fold (0.09 log units) from the limit.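

In this assay compound 3 gives > 50000 nM, again a limit of the assay. Among these compounds, no step among compound 1, compound 2 and compound 3 can be read, in size or in direction: the limit of > 50000 nM in this assay, at which 3 of the 3 values shown sit. The compounds shown leave open whether any change on the shared core gives a readable value in this assay.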